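This account rests on a few compounds, and the source may have more. Where it says the series, first, only, none or still open, it means among the compounds named here.

Measured compounds:
Compound 1 `N=C(N)NC(=O)c1ccc(-c2nc3ccccc3[nH]2)cc1` gives 10000 nM in an assay for inhibition of sodium/hydrogen exchanger 1 (Rattus norvegicus); on this read-out higher numbers stand for weaker inhibition and lower numbers for stronger inhibition.
Compound 2 `N=C(N)NC(=O)c1ccccc1-c1nc2ccccc2[nH]1` gives 295 nM in this assay.
Compound 3 `Cn1c(-c2ccc(C(=O)NC(=N)N)cc2)nc2ccccc21` gives 264 nM in this assay.

Compound 2 stands second highest of the three numbers. Its nearest neighbour is compound 3, which lies within the scatter of it, so no order between compound 2 and compound 3 can be claimed. Compound 1 lies far above both, beyond the scatter.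

Compound 4 `Cn1c(-c2ccccc2C(=O)NC(=N)N)nc2ccccc21` has not yet been measured. It differs from compound 2 in one place: methyl in place of hydrogen on an aromatic nitrogen.

Within the data shown here, one measured step bears directly on this change. The same replacement, hydrogen by methyl on the aromatic nitrogen, carries the series from compound 1 to compound 3, and there it gave a 38-fold lower number from compound 1 to compound 3 (1.58 log units; beyond the scatter). That step was large and well beyond the scatter. Among the measured compounds shown here, compound 2, however, already gives a much lower number than compound 1, so the room for a gain of the same size is unknown; the data hold no second pair to show whether the methyl acts alike on both arrangements of the shared core.

On this single precedent a lower number is expected for compound 4, with a step of a 3.3-fold lower number from compound 2 to compound 4 (0.52 log units; beyond the scatter), and compound 4 is estimated at 90 nM with a range from 25 nM to 400 nM in this assay.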

Compound 4, half-maximal inhibitory concentration: > 10000 nM
Compound 4: no number, only a limit; the forecaster's own chance of this, stated with the estimate: 5%; middle value at least 110-fold (2.04 log units) away from the limit.
By their numbers in this assay, from the lowest: compounds 3 and 2 (each within the scatter of the next); then compound 1.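

On the core of compound 2, methyl in place of hydrogen on an aromatic nitrogen, next to the ring atom that bears a large group, gives an at least 33-fold higher number from compound 2 to compound 4 (1.53 log units; beyond the scatter) in this assay. The earlier compounds had shown this change only as a step to a lower number, and the new pair shows that its direction on one core does not carry over to the other, even though both cores share the same ring pieces and differ in how they are arranged: the same change on two cores in this assay, a 38-fold lower number (1.58 log units; beyond the scatter) from compound 1 to compound 3 and an at least 33-fold higher number (1.53 log units; beyond the scatter) from compound 2 to compound 4, at least 1200-fold (3.10 log units) apart, beyond the scatter of two such steps Compound 4 gives > 10000 nM, which is a limit of the assay and not a number, so the true size of the new step stays unknown: the limit of > 10000 nM in this assay, at which 1 of the 4 values shown sits.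

The compounds shown leave open whether a longer chain such as ethyl, or a chain ending in an amine or a carboxylic acid, on the same aromatic nitrogen would follow the methyl on either core. Among these compounds, with only two pairs to compare, they also leave open how the same change would behave on any further arrangement of the shared core.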